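Chromenone Triazoles With No Measurable Inhibition So Far

The source may report more compounds than this note shows. Statements on the series, on what has been measured and on what is new or still open speak of the compounds shown alone.

Measured compounds:
Compound 1 `O=c1cc(Cn2cc(C3CC3)nn2)c2ccc(O)cc2o1` gives > 100000 nM in a functional assay on HepG2 cells (Homo sapiens) for inhibition, read by MTT assay, with a stated time of 72 h (on this read-out higher numbers stand for weaker inhibition and lower numbers for stronger inhibition), a limit of the assay rather than a number.
Compound 2 `O=c1cc(Cn2cc(CCCCl)nn2)c2ccc(O)cc2o1` gives > 100000 nM in this assay, again a limit rather than a number.

Both measured compounds share one core and differ only in the group on an aromatic carbon of the triazole ring: compound 2 carries a 3-chloropropyl in place of the cyclopropyl of compound 1. The step that the two limits leave unreadable from compound 1 to compound 2 cannot be read, since both values sit at the limit; the limit of > 100000 nM in this assay, at which 2 of the 2 values shown sit, is all that can be said of it.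

Compound 3 `O=c1cc(Cn2cc(CCO)nn2)c2ccc(O)cc2o1` is the next, unmeasured member. The change from compound 2 to compound 3 is hydroxy in place of chloromethyl on a saturated chain carbon, two bonds along the chain from an aromatic carbon. Within the data shown here, no measured step touches this position, and the only measured step, from compound 1 to compound 2, gives no size at all. There is therefore nothing in the numbers to suggest that compound 3 would fall below the limit.

For compound 3 the expected step that the limit leaves unreadable from compound 2 to compound 3 is none beyond the scatter. Compound 3 is thus estimated at 150000 nM, with a range from 40000 nM to 600000 nM, most likely reported only as a limit.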

Compound 3, half-maximal inhibitory concentration: > 100000 nM
Compound 3 ended at the assay's limit (the forecaster's own chance of this, stated with the estimate: 85%); the middle value lies beyond the limit too.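

Compound 3 also gives only a limit of the assay and not a number, so none of the steps among compound 1, compound 2 and compound 3 can be read: the limit of > 100000 nM in this assay, at which 3 of the 3 values shown sit.

The compounds shown leave open whether any other group on the shared core would give a real number in this assay, and so how much such a group matters.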